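The compounds below may be only part of what the source reports. "The series", "measured", "known", "first", "only" and "open" are said of these compounds alone.

Compound 1 `COc1ccc(Br)cc1Nc1cc(NC(=O)Nc2c(Cl)cccc2Cl)ncn1` in a functional assay on NCI-H226 cells (Homo sapiens) for inhibition, read by MTT assay, with a stated time of 48 h, tested at 10 uM (on this read-out higher numbers stand for more inhibition at the one concentration tested (going by the name of the read-out) and lower numbers for less inhibition), gives 33%.
Compound 2 `COc1ccc(Nc2cc(NC(=O)Nc3c(Cl)cccc3Cl)ncn2)cc1C` in this assay gives 50%.
Compound 3 `COc1cc(NC(=O)Nc2cc(Nc3cc(Br)ccc3OC)ncn2)cc(OC)c1` in this assay gives 42.7%.

Compound 1 and compound 2 differ in one place: 4-methoxy-3-methylphenyl in place of 5-bromo-2-methoxyphenyl on a nitrogen on an aromatic ring. That change brought a number 17 percentage points higher from compound 1 to compound 2 (beyond the scatter). Compound 3 carries a different core than compound 1: 3,5-dimethoxyphenyl in place of 2,6-dichlorophenyl on an amide-type nitrogen, which gave a number 9.7 percentage points higher from compound 1 to compound 3 (within the scatter). Compound 4 `COc1cc(NC(=O)Nc2cc(Nc3ccc(OC)c(C)c3)ncn2)cc(OC)c1` has not been measured in this assay. It stands to compound 3 as compound 2 stands to compound 1, and the change sits in the same surroundings in both pairs: 4-methoxy-3-methylphenyl in place of 5-bromo-2-methoxyphenyl on a nitrogen on an aromatic ring. The step expected here is a number 15.3 percentage points higher from compound 3 to compound 4 (beyond the scatter). Within the data shown here, it rests on the earlier a number 17 percentage points higher from compound 1 to compound 2 (beyond the scatter), the only example of this change so far, so the range is kept wide. On that basis compound 4 is expected to give about 58%, likely between 42% and 74%.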

Compound 4, a percentage reported as inhibition, at one concentration (the size of the read-out at that concentration, not a potency): 39.7%
Estimate against measurement, compound 4: 18.3 percentage points above; measured number below the stated range.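

In this assay, putting 4-methoxy-3-methylphenyl in place of 5-bromo-2-methoxyphenyl gave a number 3 percentage points lower from compound 3 to compound 4 (within the scatter), so this change did not carry over from one core to the other: the same change on two cores in this assay, a number 17 percentage points higher (beyond the scatter) from compound 1 to compound 2 and a number 3 percentage points lower (within the scatter) from compound 3 to compound 4, 20 percentage points apart, beyond the scatter of two such steps

Putting 3,5-dimethoxyphenyl in place of 2,6-dichlorophenyl gave a number 10.3 percentage points lower from compound 2 to compound 4 (beyond the scatter), so the outcome of this change also depends on the rest of the molecule: the same change on two cores in this assay, a number 9.7 percentage points higher (within the scatter) from compound 1 to compound 3 and a number 10.3 percentage points lower (beyond the scatter) from compound 2 to compound 4, 20 percentage points apart, beyond the scatter of two such steps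

These four compounds show that the two changes do not act independently here, but they do not show why, nor how either change would behave on any further core.

Going by these compounds, it remains open how the series would respond if a phenyl group carrying an amine or a carboxylic acid took the place of these aromatic groups. Each reading also comes from a single concentration, so the potency of these compounds remains unknown.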